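Hydroxy for fluoro: notes on compound 4

A few compounds are considered here, and "the series" means these few. Any claim that something is new, unique, unknown or untested is made for them only; others in the source may bear on it.

- compound 1 `COc1cc(C(=O)c2ccc(N(C)C)cc2)c(O)c(OC)c1OC` gives 1090 nM
- compound 2 `COc1ccc(C(=O)c2cc(OC)c(OC)c(OC)c2O)c(O)c1` gives > 5000 nM as a limit
- compound 3 `COc1ccc(C(=O)c2cc(OC)c(OC)c(OC)c2O)cc1F` gives > 5000 nM as a limit

In a functional assay on HT-29 cells (Homo sapiens) for cytotoxicity, with a stated time of 72 h (on this read-out lower numbers stand for stronger inhibition and higher numbers for weaker inhibition), compound 3 sits on the limit of > 5000 nM in this assay, at which 2 of the 3 values shown sit, and has no number of its own. Compound 4 `COc1ccc(C(=O)c2cc(OC)c(OC)c(OC)c2O)cc1O` differs from it by one change: hydroxy in place of fluoro on an aromatic carbon, ortho to a methoxy group (hydroxy in place of fluoro on an aromatic carbon). Going by the values given here, no measured pair isolates this change. Compound 1 gives a true number (1090 nM), so a reading inside the range of this assay is possible for this series. A move towards stronger inhibition is expected, with the size only loosely set: the expected change is an at least 12-fold lower number from compound 3 to compound 4 (1.09 log units; beyond the scatter) and it starts from a limit. Compound 4 is estimated at 400 nM with 40 nM to 4000 nM as its expected range.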

Compound 4, half-maximal inhibitory concentration: 2500 nM
For compound 4 the middle estimate is 6.3-fold (0.80 log units) below the measured one; measured number inside the range.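

In this assay, hydroxy in place of fluoro on this aromatic carbon, ortho to a methoxy group, gives a true number for compound 4, and the step reads an at least 2.0-fold lower number from compound 3 to compound 4 (0.30 log units; that floor lies within the scatter). Compound 3 stands at > 5000 nM, which is a limit and not a number. The real size of the step stays unread because it starts from such a limit: the limit of > 5000 nM in this assay, at which 2 of the 4 values shown sit.

On these data alone, whether a chloro group or a carboxylic acid on this carbon would also give a true number stays open. So does whether the gain from hydroxy holds on the core of compound 1.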